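A few compounds are considered here, and "the series" means these few. Any claim that something is new, unique, unknown or untested is made for them only; others in the source may bear on it.

Working notes on the series. Compound 1 `COc1cc(/C=C/C(=O)c2ccc(N)c(-c3ccc(F)cc3)c2)ccc1O` carries 4-hydroxy-3-methoxyphenyl on a double-bonded chain carbon bound to a double-bonded chain carbon; in an assay on A549 cells for inhibition of transcription factor p65 (Homo sapiens), read by fluorescence, with a stated time of 2 h (a lower number here means a stronger inhibitor, a higher number a weaker inhibitor), compound 1 gives 6830 nM. Compound 2 `COc1ccc(/C=C/C(=O)c2ccc(N)c(-c3ccc(F)cc3)c2)cc1` carries 4-methoxyphenyl on that same chain carbon. In this assay compound 2 is recorded only as a limit, > 50000 nM, and no number stands for it. The step of an at least 7.3-fold higher number from compound 1 to compound 2 (0.86 log units; beyond the scatter) is therefore read against the limit of > 50000 nM in this assay, at which 1 of the 2 values shown sits: its direction is a weakening, its full size open.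

Compound 3 `Nc1ccc(C(=O)/C=C/c2ccc(O)c(F)c2)cc1-c1ccc(F)cc1` is not yet measured. Its difference from compound 2 is 3-fluoro-4-hydroxyphenyl in place of 4-methoxyphenyl on a double-bonded chain carbon bound to a double-bonded chain carbon. Going by the values given here, the only measured step that bears on this ring is an at least 7.3-fold higher number from compound 1 to compound 2 (0.86 log units; beyond the scatter), in which the hydroxyl-bearing ring of compound 1 gave the lower number. Compound 3 again carries a hydroxyl on that ring, with a fluorine instead of the methoxy of compound 1, so a move back toward the number of compound 1 is expected rather than no change. For compound 3 the step of an at least 5.5-fold lower number from compound 2 to compound 3 (0.74 log units; beyond the scatter) is expected in this assay. Compound 3 is estimated at 9000 nM, within 2500 nM to 35000 nM, with a real chance that this assay again reports only a limit.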

Compound 3, half-maximal inhibitory concentration: > 50000 nM
Compound 3 gave a limit, no number; the forecaster's own chance of this, stated with the estimate: 25%; middle value at least 5.5-fold (0.74 log units) from the limit.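

In this assay, fluoro in place of methoxy on the hydroxyl-bearing ring gives an at least 7.3-fold higher number from compound 1 to compound 3 (0.86 log units; beyond the scatter), so the hydroxyl without the methoxy does not retain the measurable inhibition of compound 1. Among the three compounds, only compound 1, with 4-hydroxy-3-methoxyphenyl, has a number; loss of the hydroxyl in compound 2 and exchange of the methoxy in compound 3 each leave the series at the limit. Compound 2 and compound 3 both stand only as limits, and the step between them cannot be read: the limit of > 50000 nM in this assay, at which 2 of the 3 values shown sit.

On these data alone, how far compound 2 and compound 3 lie beyond that limit remains open, and so does any order between 4-methoxyphenyl and 3-fluoro-4-hydroxyphenyl at this position. Also open, as far as these compounds go, is whether the methoxy itself is what matters on this ring, or whether an ethoxy or a chlorine in its place, or an amine in place of the hydroxyl, would return a number near that of compound 1.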